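The source may report more compounds than this note shows. Statements on the series, on what has been measured and on what is new or still open speak of the compounds shown alone.

Compound 3 `Cc1cc(SC2CCCCC2)nc(Nc2ccc(C#N)cc2)n1` is one of three compounds tested in an ADME assay on MT4 cells (Homo sapiens) for cytotoxicity, read by MTT assay; on this read-out lower numbers stand for higher toxicity in this test and higher numbers for lower toxicity in this test. In this assay compound 3 gives >= 192000 nM, which is a limit of the assay and not a number. It sits at the limit of >= 192000 nM in this assay, at which 1 of the 3 values shown sits, the highest point among the values shown. Compound 2 `Cc1cc(NC2CCCCC2)nc(Nc2ccc(C#N)cc2)n1` gives 340 nM in this assay, and compound 1 `N#Cc1ccc(Nc2nccc(NC3CCCC3)n2)cc1` gives 9130 nM.

The piece now moves from compound 3 to compound 4 `Cc1cc(NC2CCCC2)nc(Nc2ccc(C#N)cc2)n1`, which has not yet been measured in this assay. The change is cyclopentylamino in place of cyclohexylsulfanyl on an aromatic carbon.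

For the measured compounds named here, one measured step bears on it directly: an at least 560-fold higher number from compound 2 to compound 3 (2.75 log units; beyond the scatter). That step ran in the opposite direction, exchanging an amino link for a sulfanyl link, and it was large. The change to compound 4 restores an amino link, now carrying a five-membered ring rather than a six-membered one. Going by the values given here, compound 1, which also carries cyclopentylamino but lacks the methyl group, stands at a higher number than compound 2; no single step joins them, so only their two values are known. A large step downward from compound 3 is therefore expected, landing compound 4 somewhere between the values of compound 2 and compound 1.

The estimate for compound 4 is 1500 nM, with a range from 300 nM to 10000 nM, which as a step means an at least 120-fold lower number from compound 3 to compound 4 (2.10 log units; beyond the scatter).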

Compound 4, half-maximal cytotoxic concentration: 310 nM
Beside the measured number, compound 4's estimate is 4.8-fold (0.68 log units) above it; the range from low to high includes it.
By their numbers in this assay, from the lowest: compounds 4 and 2 (each within the scatter of the next); then compound 1. At a limit, above all of these: compound 3.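

Compound 3 stands at a limit of this assay, which is not a number: the limit of >= 192000 nM in this assay, at which 1 of the 4 values shown sits.

Starting from that limit, an at least 610-fold lower number from compound 3 to compound 4 (2.79 log units; beyond the scatter), which matches in direction and scale the earlier exchange of the link, an at least 560-fold higher number from compound 2 to compound 3 (2.75 log units; beyond the scatter), so at this position compound 3 stands apart from both methyl-bearing amino compounds, whether the amino link carries a five-membered or a six-membered ring. Ring size on the amino link leaves the read-out within the scatter, a 1.1-fold lower number from compound 2 to compound 4 (0.04 log units; within the scatter), whereas the methyl group now has a single step of its own with a large difference, a 29-fold lower number from compound 1 to compound 4 (1.47 log units; beyond the scatter), and with it the number moves toward higher toxicity in this test.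

The compounds shown leave open whether an oxygen link or a methylene link at the same position would behave like the sulfanyl link or like the amino link. They also leave open whether the sulfanyl link would give a similar result with a cyclopentyl ring, or on a core without the methyl group, and why the link and the methyl group matter here.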